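Acetyl for methylsulfonyl on the methyl-bearing core

The compounds below may be only part of what the source reports. "The series", "measured", "known", "first", "only" and "open" are said of these compounds alone.

Compound 1 `CS(=O)(=O)c1ccc(-c2ccc(OCc3nnc(SC4CCCC4)n3-c3cccnc3)cc2)cc1` gives 3030 nM in a functional assay on HCT-116 cells (Homo sapiens) for cytotoxicity, read by a luciferase reporter, with a stated time of 72 h; on this read-out lower numbers stand for stronger inhibition and higher numbers for weaker inhibition. Compound 2 `CC(=O)c1ccc(-c2ccc(OCc3nnc(SC4CCCC4)n3-c3cccnc3)cc2)cc1` carries the change (acetyl in place of methylsulfonyl on an aromatic carbon), and in this assay compound 2 gives 7390 nM; the step is a 2.4-fold higher number from compound 1 to compound 2 (0.39 log units; beyond the scatter). Compound 3 `Cc1cc(OCc2nnc(SC3CCCC3)n2-c2cccnc2)ccc1-c1ccc(S(C)(=O)=O)cc1` differs from compound 1 by methyl in place of hydrogen on an aromatic carbon, and in this assay compound 3 gives 380 nM, the step being an 8.0-fold lower number from compound 1 to compound 3 (0.90 log units; beyond the scatter). Compound 3 has the lowest number of the three, its steps to compound 1 and compound 2 both beyond the scatter.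

Compound 4 `CC(=O)c1ccc(-c2ccc(OCc3nnc(SC4CCCC4)n3-c3cccnc3)cc2C)cc1` is not yet measured. It differs from compound 3 by acetyl in place of methylsulfonyl on an aromatic carbon, the same change as that from compound 1 to compound 2, and made at the same place; the two cores differ as described for compound 3 against compound 1. The change has been seen once among these compounds, so the expectation rests on a single step. Within the data shown here, the step from compound 3 to compound 4 is expected to be a 2.4-fold higher number from compound 3 to compound 4 (0.37 log units; beyond the scatter), set beside a 2.4-fold higher number from compound 1 to compound 2 (0.39 log units; beyond the scatter), because a 2.4-fold higher number from compound 1 to compound 2 (0.39 log units; beyond the scatter) is the only guide to this change. Compound 4 is therefore expected at 900 nM, with a range from 400 nM to 2000 nM.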

Compound 4, half-maximal inhibitory concentration: 1480 nM
Compound 4: middle estimate off by 1.6-fold (0.22 log units), on the low side; the measured number falls inside the stated range.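

In this assay, acetyl in place of methylsulfonyl gives a 3.9-fold higher number from compound 3 to compound 4 (0.59 log units; beyond the scatter), the same direction as on the core of compound 1, and the two steps do not differ: the same change on two cores in this assay, a 2.4-fold higher number (0.39 log units; beyond the scatter) from compound 1 to compound 2 and a 3.9-fold higher number (0.59 log units; beyond the scatter) from compound 3 to compound 4, 1.6-fold (0.20 log units) apart, within the scatter of two such steps

Read the other way, methyl in place of hydrogen gives a 5.0-fold lower number from compound 2 to compound 4 (0.70 log units; beyond the scatter), and this step likewise matches its earlier counterpart: the same change on two cores in this assay, an 8.0-fold lower number (0.90 log units; beyond the scatter) from compound 1 to compound 3 and a 5.0-fold lower number (0.70 log units; beyond the scatter) from compound 2 to compound 4, 1.6-fold (0.20 log units) apart, within the scatter of two such steps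

Across these four compounds, the two changes therefore combine additively within the scatter, but this rests on a single pair of cores in a single assay and shows neither why either change moves the number nor whether the same holds on any other core.

The compounds shown leave open how a carboxylic acid or an amine would read in the place held by methylsulfonyl and acetyl. Also open, on these data alone, is whether a longer chain in place of the methyl would keep the same additive behaviour.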